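Replacing the hydroxymethylethyl group with a dimethylisoxazole

The compounds below may be only part of what the source reports. "The series", "measured", "known", "first", "only" and "open" are said of these compounds alone.

Compound 2 `Cc1cc(C)c(CN2CCc3c(Cl)cc([C@H](C)CO)c(Cl)c3C2=O)c(=O)[nH]1` gives 17 nM in an assay for inhibition of histone-lysine N-methyltransferase EZH2 variant Y641N (Homo sapiens), read by scintillation counting, with a stated time of 60 min, in the presence of a further agent that is not named here (a higher number here means a weaker inhibitor, a lower number a stronger inhibitor), the highest of the two single numbers here. Compound 1 `Cc1cc(C)c(CN2CCc3c(Cl)cc([C@H](CO)[C@H]4CCOC4)c(Cl)c3C2=O)c(=O)[nH]1` gives 0.24 nM, and the step of a 71-fold higher number from compound 1 to compound 2 (1.85 log units; beyond the scatter) is large. Compound 3 `Cc1cc(C)c(CN2CCc3c(Cl)cc(C(CO)C4CCOC4)c(Cl)c3C2=O)c(=O)[nH]1` gives 150 nM; 0.38 nM (2 entries), two entries that differ widely (the several entries of compound 3 in this assay, 150 nM; 0.38 nM (2 entries)). The change to compound 4 `Cc1cc(C)c(CN2CCc3c(Cl)cc(-c4c(C)noc4C)c(Cl)c3C2=O)c(=O)[nH]1` is 3,5-dimethyl-1,2-oxazol-4-yl in place of 1-(hydroxymethyl)ethyl on an aromatic carbon. For the measured compounds named here, no measured step covers this replacement; the only measured step concerns a different exchange at the same carbon, so it tells only that this position moves the number strongly. Compound 4 is therefore expected to give 5 nM, with a range from 0.8 nM to 40 nM, an expected step of a 3.4-fold lower number from compound 2 to compound 4 (0.53 log units; beyond the scatter) toward a lower number, though uncertain.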

Compound 4, inhibition constant: 1.15 nM
Compound 4: middle estimate off by 4.3-fold (0.64 log units), on the high side; low and high end bracket the measured number.
By their numbers in this assay, from the lowest: compound 1; then compound 4; then compound 2.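

Exchanging 1-(hydroxymethyl)ethyl for 3,5-dimethyl-1,2-oxazol-4-yl on this aromatic carbon gives a 15-fold lower number from compound 2 to compound 4 (1.17 log units; beyond the scatter), which shows that an aromatic ring with 0 hydrogen-bond donors can take this position and still give a low number. The group of compound 1 keeps a smaller edge, with a 4.8-fold higher number from compound 1 to compound 4 (0.68 log units; beyond the scatter). Compound 3 offers no firmer comparison: the several entries of compound 3 in this assay, 150 nM; 0.38 nM (2 entries)

From the compounds shown here alone, it remains open whether the two methyl groups of the entering ring matter to the number. Going by these compounds, it is also open how an amine or a carboxylic acid would fare on this carbon.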